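A Carboxy Group at the End of a Side Chain

The source may report more compounds than this note shows. Statements on the series, on what has been measured and on what is new or still open speak of the compounds shown alone.

- compound 1 `COOC1(OOC)CCCCCCCCCCC1` gives 1500 nM
- compound 2 `COOC1(OOCCCCCCOC2CCOCC2)CCCCCCCCCCC1` gives 7600 nM

Of the two numbers in a functional assay on FM3A cells (Mus musculus) for cytotoxicity (a higher number here means that more compound is needed for the effect, a lower number that less compound is needed), compound 2 holds the higher one, and its gap to compound 1 lies beyond the scatter. Compound 3 `COOC1(OOCCCCCC(=O)O)CCCCCCCCCCC1` has not been measured yet. It differs from compound 2 by carboxy in place of ((oxan-4-yl)oxy)methyl on a saturated chain carbon, five bonds along the chain from an oxygen in one place, with carboxy in place of ((oxan-4-yl)oxy)methyl on a saturated chain carbon, five bonds along the chain from an oxygen. For the measured compounds named here, no measured pair shows this change, so the expectation is loose. The expected step of a 1.6-fold higher number from compound 2 to compound 3 (0.20 log units; within the scatter) in this assay is small and upward, probably within the scatter. For compound 3 the estimated value is 12000 nM with a range from 3500 nM to 40000 nM expected.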

Compound 3, half-maximal effective concentration: 14000 nM
For compound 3 the middle estimate is 1.2-fold (0.07 log units) below the measured one, within the range that was stated.
By their numbers in this assay, from the lowest: compound 1; then compounds 2 and 3 (each within the scatter of the next).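

In this assay, carboxy in place of ((oxan-4-yl)oxy)methyl on a saturated chain carbon, five bonds along the chain from an oxygen, gives a 1.8-fold higher number from compound 2 to compound 3 (0.27 log units; within the scatter), so the ring-bearing group and the much smaller carboxy cannot be told apart here. Putting 4-carboxybutyl in place of hydrogen gives a 9.3-fold higher number from compound 1 to compound 3 (0.97 log units; beyond the scatter), so more compound is needed once this side chain is present. No measurement shown explains either step. The compounds shown leave open whether an amine or an amide in place of carboxy would give a similar number. Going by these compounds, whether a shorter or longer chain carrying carboxy would shift it also remains open.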